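The source may report more compounds than this note shows. Statements on the series, on what has been measured and on what is new or still open speak of the compounds shown alone.

Working notes on the series.

Compound 1 `O=C(CCNC(=O)c1cc(-c2ccc(F)cc2)[nH]n1)NO` is the short-linker hydroxamic acid of the set. In an assay on cells for inhibition of protein deacetylase HDAC6 (Homo sapiens), read by fluorescence, with stated times of 15 min and 60 min (on this read-out lower numbers stand for stronger inhibition and higher numbers for weaker inhibition), compound 1 gives only a limit, > 5000 nM, and no number; it stands at the limit of > 5000 nM in this assay, at which 1 of the 2 values shown sits, so only the weak side of the range is known for it. Within the data shown here, compound 2 `CCc1cc(-c2ccc(F)cc2)nn1Cc1ccc(C(=O)NO)cc1`, the benzyl-linked analogue, is the one measured member with a number: in this assay compound 2 gives 35 nM.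

The next step lengthens the chain of compound 1. Compound 3 `O=C(CCCCNC(=O)c1cc(-c2ccc(F)cc2)[nH]n1)NO` differs from compound 1 by 2-(hydroxycarbamoyl)ethyl in place of hydroxycarbamoyl on a saturated chain carbon, two bonds along the chain from an amide-type nitrogen. Among the measured compounds shown here, no measured pair of the set isolates a change of this kind, so the step cannot be calibrated from the data. Extending the hydroxamate-bearing chain is expected to move this assay toward stronger inhibition rather than leave it within the scatter, though the starting point is only a limit. The estimate is that the step from compound 1 to compound 3 is an at least 3.3-fold lower number from compound 1 to compound 3 (0.52 log units; beyond the scatter). Compound 3 is expected to give about 1500 nM, in the range 300 nM to 8000 nM.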

Compound 3, half-maximal inhibitory concentration: 275 nM
Estimate against measurement, compound 3: 5.5-fold (0.74 log units) above; the measured number lies below the stated range.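

Among these compounds, replacing hydroxycarbamoyl with 2-(hydroxycarbamoyl)ethyl on a saturated chain carbon, two bonds along the chain from an amide-type nitrogen, gives the first reading of chain length on the shared core: in this assay the change gives an at least 18-fold lower number from compound 1 to compound 3 (1.25 log units; beyond the scatter). Among the compounds shown here, this place is therefore sensitive to chain length, at least for this one pair, and compound 3 gives the amide-linked pair its only measured number. The true size of the step stays open-ended, as compound 1 is only a limit: the limit of > 5000 nM in this assay, at which 1 of the 3 values shown sits.

On these data alone, whether a longer chain than that of compound 3 would strengthen inhibition further or weaken it remains open, as does whether a carboxylic acid on the same chain in place of the hydroxamic acid keeps any inhibition. Compound 2 differs from compound 3 in more than one place, so that pair gives no reading of the linker.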